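The source may report more compounds than this note shows. Statements on the series, on what has been measured and on what is new or still open speak of the compounds shown alone.

Compound 1 `CC(=O)c1ccc(N2CCN(C(=O)c3oc(C)nc3-c3ccccc3)CC2)cc1` is reported in a functional assay on HL-60 cells (Homo sapiens) for inhibition, read by MTT assay, with a stated time of 72 h (a lower number here means a stronger inhibitor, a higher number a weaker inhibitor), as "not active" (no number reported), so no single number fixes where compound 1 stands. Two other members of the set give numbers: compound 2 `Cc1ccc(C)c(N2CCN(C(=O)c3oc(C)nc3-c3ccccc3F)CC2)c1` gives 319 nM in this assay, and compound 3 `CCc1nc(-c2ccc(C(C)C)cc2)c(C(=O)N2CCN(c3cccc(OC)c3)CC2)o1` gives 887 nM. Compound 4 `Cc1cc(C)cc(N2CCN(C(=O)c3oc(C)nc3-c3ccccc3)CC2)c1` differs from compound 1 in one place: 3,5-dimethylphenyl in place of 4-acetylphenyl on an amine nitrogen in a ring. Within the data shown here, no measured pair covers this move, so its size cannot be read from the data; given that compound 2 with 319 nM and compound 3 with 887 nM both carry a substituted phenyl on an amine nitrogen in a ring and reach measurable inhibition, compound 4 is expected to return a number rather than an inactive call. Compound 4 is estimated at 600 nM in this assay, within 150 nM to 2500 nM.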

Compound 4, half-maximal inhibitory concentration: 34.5 nM
The estimate for compound 4 lay 17-fold (1.24 log units) above the measured number; the measured number lies below the stated range.
By their numbers in this assay, from the lowest: compound 4; then compound 2; then compound 3.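

No step can be read for compound 4: compound 1, its only one-place partner here, carries no number. The compounds shown leave open how far the 4-acetylphenyl and 3,5-dimethylphenyl groups differ in size of effect. No evidence on this result is available.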